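This account rests on a few compounds, and the source may have more. Where it says the series, first, only, none or still open, it means among the compounds named here.

Measured so far:
compound 1 `Nc1ncn(CCC2(N)OC(=O)C(OCc3ccccc3)=C2OCc2ccccc2)c(=O)n1` — in an ADME assay on WI-38 cells (Homo sapiens) for inhibition, read by MTT assay, with a stated time of 72 h (a lower number here means a stronger inhibitor, a higher number a weaker inhibitor), compound 1 gives > 100000 nM
compound 2 `O=C1O/C(=C\Cn2ccc(NC(=O)c3ccccc3)nc2=O)C(OCc2ccccc2)=C1OCc1ccccc1` — in this assay compound 2 gives 8490 nM

Compound 1 stands at the edge of what the measurement can report: its value of > 100000 nM is a limit, not a number, as the limit of > 100000 nM in this assay, at which 1 of the 2 values shown sits, records. Compound 2, by contrast, gives a real number of 8490 nM in this assay. Compound 3 `NC1(CCn2ncc(=O)[nH]c2=O)OC(=O)C(OCc2ccccc2)=C1OCc1ccccc1` differs from compound 1 in one place: a group of 8 heavy atoms (3 carbon, 3 nitrogen, 2 oxygen; one six-membered aromatic ring with 3 hetero atoms) in place of a group of 8 heavy atoms (3 carbon, 4 nitrogen, 1 oxygen; one six-membered aromatic ring with 3 hetero atoms), on a saturated chain carbon, two bonds along the chain from a saturated ring carbon. Going by the values given here, no measured pair shows a change of this kind, so its effect cannot be read off the numbers. With compound 1 already at the limit, the expectation in this assay is no step beyond the usual scatter, in either direction. The step this implies, a step that the limit leaves unreadable from compound 1 to compound 3, is expected to lie within that scatter. Compound 3 is therefore estimated at 150000 nM, within a range of 30000 nM to 600000 nM, and will most likely again be reported only as a limit.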

Compound 3, half-maximal inhibitory concentration: > 100000 nM
Compound 3: a limit, no number; the forecaster's own chance of this, stated with the estimate: 75%; the middle value does not contradict the limit.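

Compound 3, like compound 1, gives only a limit and not a number in this assay, so the step between these two compounds cannot be read: the limit of > 100000 nM in this assay, at which 2 of the 3 values shown sit.

The compounds shown leave open whether exchanging the ring group on the saturated chain carbon changes the inhibition at all.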